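The source may hold more compounds than are shown below. What is called first, only, known or untested is meant among the compounds shown, and "the series" means these compounds.

Values so far in a functional assay on WM 266-4 cells (Homo sapiens) for antiproliferative activity, read by MTT assay, with a stated time of 24 h; a lower number here means a stronger inhibitor of growth, a higher number a weaker inhibitor of growth:
- compound 1 `O=C(c1cncc(Br)c1)N1N=C(c2ccc(Cl)cc2)CC1c1ccc(OCc2ccccc2)cc1`: 8130 nM
- compound 2 `Cc1ccc(C(=O)N2N=C(c3ccc(Cl)cc3)CC2c2ccc(OCc3ccccc3)cc2)c(Cl)n1`: 11400 nM
- compound 3 `O=C(c1cccnc1Cl)N1N=C(c2ccc(Cl)cc2)CC1c1ccc(OCc2ccccc2)cc1`: 7710 nM

The three values form a single level: a 1.1-fold lower number from compound 1 to compound 3 (0.02 log units; within the scatter), a 1.5-fold lower number from compound 2 to compound 3 (0.17 log units; within the scatter) and a 1.4-fold higher number from compound 1 to compound 2 (0.15 log units; within the scatter) all lie within the scatter. Compound 3 at 7710 nM therefore stands level with the other two.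

The next compound is compound 4 `O=C(c1cccnc1Cl)N1N=C(c2ccc(Cl)cc2)CC1c1ccc(Br)cc1`, with bromo in place of benzyloxy on an aromatic carbon, para to a large group: bromo in place of benzyloxy on an aromatic carbon. Every measured step changes the group on the carbonyl carbon, and all three measured compounds carry benzyloxy. None of these steps gives a size for this change, so the expectation is weakly supported and starts from compound 3 at 7710 nM. A modest rise in the number is expected, though a fall cannot be excluded, and the expected step is a 1.7-fold higher number from compound 3 to compound 4 (0.23 log units; within the scatter). In this assay the estimate for compound 4 is 13000 nM, with an expected range of 3500 nM to 40000 nM.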

Compound 4, concentration for 50% growth inhibition: 7450 nM
For compound 4 the middle estimate is 1.7-fold (0.24 log units) above the measured one, within the range that was stated.
By their numbers in this assay, from the lowest: compounds 4, 3, 1 and 2 (each within the scatter of the next).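

In this assay, bromo in place of benzyloxy on an aromatic carbon, para to a large group, gives a 1.0-fold lower number from compound 3 to compound 4 (0.01 log units; within the scatter) and so leaves the number level. Among the compounds shown here, this is the first step read away from the carbonyl carbon, and it shows that, in this pair, the whole benzyloxy group with its six-membered aromatic ring can give way to a single bromine atom without a step beyond the scatter. No measured data bear on why the two groups read level.

As far as these compounds go, this change has been read only with 2-chloropyridin-3-yl on the carbonyl carbon, so it remains open whether the level holds with the other carbonyl groups. Also open, from the compounds shown here alone, is whether an amine, a carboxylic acid or a longer chain at this position would stay on the same level.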